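Hydrogen in Place of Methoxy: Expectation for Compound 3

The source may report more compounds than this note shows. Statements on the series, on what has been measured and on what is new or still open speak of the compounds shown alone.

Measured compounds:
compound 1 `COc1ccc(NC(=O)Nc2nc(Sc3c[nH]c4ccccc34)cc(N3CCN(Cc4ccccc4)CC3)n2)cc1` — 21400 nM
compound 2 `Cc1cc(Cl)ccc1NC(=O)Nc1nc(NC2CC2)cc(Sc2c[nH]c3ccccc23)n1` — 9740 nM

In a functional assay on HepG2 cells (Homo sapiens) for inhibition, with a stated time of 72 h (on this read-out lower numbers stand for stronger inhibition and higher numbers for weaker inhibition), compound 1 gives 21400 nM, the highest of the two numbers shown. Compound 2 gives 9740 nM, a lower number, and the gap between the two lies beyond the usual scatter. Compound 3 `O=C(Nc1ccccc1)Nc1nc(Sc2c[nH]c3ccccc23)cc(N2CCN(Cc3ccccc3)CC2)n1` has not been measured; it differs from compound 1 in a single place: hydrogen in place of methoxy on an aromatic carbon. Within the data shown here, no measured pair shows this change, so nothing within these data tells how much hydrogen in place of methoxy on an aromatic carbon moves the read-out. The step is therefore expected to be small, a 1.0-fold higher number from compound 1 to compound 3 (0.01 log units; within the scatter), with no clear direction and most likely no shift beyond the scatter. On that basis compound 3 is estimated at 22000 nM, with a range from 8000 nM to 55000 nM.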

Compound 3, half-maximal inhibitory concentration: 8160 nM
Beside the measured number, compound 3's estimate is 2.7-fold (0.43 log units) above it; the range from low to high includes it.
By their numbers in this assay, from the lowest: compounds 3 and 2 (each within the scatter of the next); then compound 1.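

In this assay, hydrogen in place of methoxy on an aromatic carbon gives a 2.6-fold lower number from compound 1 to compound 3 (0.42 log units; beyond the scatter) and so moves the read-out beyond the scatter, towards stronger inhibition. This single pair shows that the carbon para to a large group is not indifferent to what it carries, and that the 4-methoxyphenyl group is not required for the inhibition seen with this core, since plain phenyl gives a modest gain. Nothing at hand accounts for the shift.

The compounds shown leave open whether a chlorine atom, a methyl group or a hydroxyl group on this same carbon would stay close to hydrogen or fall back towards methoxy. They also leave open whether the same change would give a similar step on a core carrying a different amine in place of the benzylpiperazine.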